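A few compounds are considered here, and "the series" means these few. Any claim that something is new, unique, unknown or untested is made for them only; others in the source may bear on it.

Of the compounds shown here, three that share one core have been measured in a physicochemical assay for lipophilicity, using the shake flask method, in phosphate buffer, measured as octanol-water partition, at pH 7.4; on this read-out lower numbers stand for lower lipophilicity and higher numbers for higher lipophilicity. Compound 1 `COc1cc(-c2cc(C(=O)O)c3ccccc3n2)ccc1OCC(=O)Nc1ccccc1C` gives 0.8, compound 2 `COc1cc(-c2cc(C(=O)O)c3ccccc3n2)ccc1OCC(=O)Nc1ccccc1Cl` gives 1.6, and compound 3 `COc1cc(-c2cc(C(=O)O)c3ccccc3n2)ccc1OCC(=O)Nc1cccc(C(F)(F)F)c1` gives 1.3. Among these, compound 2 holds the highest of the three numbers, though compound 3 is within the scatter of it, and only compound 1 sits clearly apart: the step of a number 0.80 log units higher from compound 1 to compound 2 (beyond the scatter) is beyond the scatter, as is a number 0.50 log units higher from compound 1 to compound 3 (beyond the scatter), while a number 0.30 log units lower from compound 2 to compound 3 (within the scatter) is within it.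

Compound 4 `COc1cc(-c2cc(C(=O)O)c3ccccc3n2)ccc1OCC(=O)NC1CCCCC1` has not yet been measured in this assay. It differs from compound 2 in one place: cyclohexyl in place of 2-chlorophenyl on an amide-type nitrogen. None of the three measured steps bears directly on this change, since each of them swaps one substituted aromatic ring for another rather than an aromatic ring for a non-aromatic one. The measured steps thus give no direction for this change, and no step beyond the scatter is expected. On that basis compound 4 is estimated at 1.5, in a range from 0.9 to 2.1, meaning an expected step of a number 0.10 log units lower from compound 2 to compound 4 (within the scatter).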

Compound 4, distribution coefficient: 0.8
The estimate for compound 4 lay 0.70 log units above the measured number, outside the stated range (below it).
By their numbers in this assay, from the lowest: compounds 1 and 4 (each within the scatter of the next); then compounds 3 and 2 (each within the scatter of the next).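

In this assay a non-aromatic ring on the amide-type nitrogen can clearly move the number: cyclohexyl in place of 2-chlorophenyl gives a number 0.80 log units lower from compound 2 to compound 4 (beyond the scatter) and in place of 3-(trifluoromethyl)phenyl gives a number 0.50 log units lower from compound 3 to compound 4 (beyond the scatter) while in place of 2-methylphenyl it gives no change at the digits printed from compound 1 to compound 4 (within the scatter) and so stays within the scatter. Swapping an aromatic ring for cyclohexyl therefore has no single outcome at this position, since the size of the step varies with the aromatic group that leaves, and compound 1 is the one that goes against the drop seen from compound 2 and compound 3. Nothing available here explains why these steps differ.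

An unsubstituted phenyl group on this nitrogen would show what the bare aromatic ring gives without chlorine, methyl or trifluoromethyl. Also open, as far as these compounds go, is how a smaller cyclopentyl ring, a straight butyl chain or a ring carrying an amine would compare with cyclohexyl.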